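Losing the 3-methylbut-2-en-1-yl chain from compound 3

The source may hold more compounds than are shown below. What is called first, only, known or untested is meant among the compounds shown, and "the series" means these compounds.

In a functional assay on HeLa cells (Homo sapiens) for inhibition, read by MTT assay, with a stated time of 72 h (on this read-out higher numbers stand for weaker inhibition and lower numbers for stronger inhibition), compound 1 `COc1cc(/C=C/C(=O)c2c(OC)cc(O)c(CC=C(C)C)c2O)ccc1O` gives 33800 nM, compound 2 `COc1ccccc1/C=C/C(=O)c1c(OC)cc(O)c(CC=C(C)C)c1O` gives 19700 nM and compound 3 `COc1cc(O)c(CC=C(C)C)c(O)c1C(=O)/C=C/c1cccc([N+](=O)[O-])c1` gives 16500 nM. Compound 3 stands at the low end of these numbers, level with compound 2 (a 1.2-fold lower number from compound 2 to compound 3 (0.08 log units; within the scatter)) and only modestly apart from compound 1 (a 2.0-fold lower number from compound 1 to compound 3 (0.31 log units; beyond the scatter)). The remaining step, a 1.7-fold lower number from compound 1 to compound 2 (0.23 log units; within the scatter), also stays within the scatter. All three steps exchange one phenyl group for another and leave the 3-methylbut-2-en-1-yl chain in place.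

The next compound, compound 4 `COc1cc(O)cc(O)c1C(=O)/C=C/c1cccc([N+](=O)[O-])c1`, changes that chain instead: hydrogen in place of 3-methylbut-2-en-1-yl on an aromatic carbon. For the measured compounds named here, no measured step touches this place, so the series gives no direct measure of the change. The largest phenyl exchange, a 2.0-fold lower number from compound 1 to compound 3 (0.31 log units; beyond the scatter), shows only how narrow the numbers have been while the chain stayed on, and it does not set a limit for removing the chain. A move towards weaker inhibition is therefore a judgement, and the range must stay wide. The expected step is a 2.4-fold higher number from compound 3 to compound 4 (0.38 log units; beyond the scatter), which would exceed the phenyl exchanges in size. The estimated value for compound 4 is 40000 nM, with an expected range of 18000 nM to 90000 nM.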

Compound 4, half-maximal inhibitory concentration: 15500 nM
For compound 4 the middle estimate is 2.6-fold (0.41 log units) above the measured one, outside the stated range (below it).
By their numbers in this assay, from the lowest: compounds 4, 3, 2 and 1 (each within the scatter of the next, the first and the last beyond it).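

In this assay, for the compounds shown here, the first direct reading at this place, on an aromatic carbon para to a methoxy group and ortho to two hydroxy groups, is a 1.1-fold lower number from compound 3 to compound 4 (0.03 log units; within the scatter), so compound 3 and compound 4 stand level. Every earlier compound carried the 3-methylbut-2-en-1-yl chain, so the phenyl exchanges could not show that, with the 3-nitrophenyl group in place, hydrogen on this carbon reads the same as the chain within the scatter. No measured evidence on the compounds bears on this result.

The finding rests on one matched pair, and the compounds shown do not tell whether the chain can be lost equally with the 4-hydroxy-3-methoxyphenyl group of compound 1 or the 2-methoxyphenyl group of compound 2. They also leave open how this aromatic carbon would read with a different substituent, such as a methyl group, a longer chain, an amine or a carboxylic acid, since only 3-methylbut-2-en-1-yl and hydrogen have been compared here.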